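The source may report more compounds than this note shows. Statements on the series, on what has been measured and on what is new or still open speak of the compounds shown alone.

Three compounds have been tested in an ADME assay on L1210/0 cells (Mus musculus) for cytotoxicity, with a stated time of 48 h (on this read-out higher numbers stand for weaker inhibition and lower numbers for stronger inhibition), and every result is a limit of the assay rather than a number:

compound 1 `Nc1ncnc2c1ncn2C[C@@H]1C[C@H](O)c2ccccc21`, > 200000 nM;
compound 2 `Oc1ncnc2c1ncn2C[C@@H]1C[C@H](O)c2ccccc21`, > 200000 nM;
compound 3 `Nc1ncnc2c1ncn2[C@@H]1CCC[C@H]1CO`, > 200000 nM.

Compound 2 arises from compound 1 by hydroxy in place of amino on an aromatic carbon. The step that the two limits leave unreadable from compound 1 to compound 2 cannot be read, because of the limit of > 200000 nM in this assay, at which 3 of the 3 values shown sit. How the core of compound 1 differs from the core of compound 3 is not broken down here.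

Compound 4 `OC[C@@H]1CCC[C@H]1n1cnc2c(O)ncnc21`, not yet measured, arises from compound 3 by hydroxy in place of amino on an aromatic carbon. The surroundings of the change are described in the same words for both pairs, so it is the same change.

In this assay this change produced no readable step, and compound 3 itself sits at the limit. Compound 4 is therefore expected to remain at the limit, with an expected step that the limit leaves unreadable from compound 3 to compound 4. This expectation rests on compound 3, whose result > 200000 nM is a limit, and on the unreadable step that the two limits leave unreadable from compound 1 to compound 2. Compound 4 is estimated at 300000 nM, between 100000 nM and 3000000 nM, most likely reported once more only as a limit.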

Compound 4, half-maximal inhibitory concentration: > 200000 nM
Compound 4: a limit, no number; the forecaster's own chance of this, stated with the estimate: 90%; the middle value does not contradict the limit.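

In this assay compound 4 gives > 200000 nM, which is a limit and not a number. Among these compounds, no step from compound 3 to compound 4 can be read, because both results are limits: the limit of > 200000 nM in this assay, at which 4 of the 4 values shown sit. The compounds shown leave open how far any of them lies beyond that limit, and whether hydroxy in place of amino makes any difference in this read-out.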